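The source may hold more compounds than are shown below. What is called first, only, known or untested is meant among the compounds shown, and "the series" means these compounds.

Measured compounds:
compound 1 `CC1CC/C(=N\Nc2ccccc2F)c2ncc(C(=O)O)c(=O)n21`: 5 umol/kg
compound 2 `CC1CC/C(=N\Nc2cccc(Br)c2)c2ncc(C(=O)O)c(=O)n21`: 0.4 umol/kg
compound 3 `CC1CC/C(=N\Nc2ccc(Br)cc2)c2ncc(C(=O)O)c(=O)n21`: 0.8 umol/kg

All three share one core and differ only in the aryl group attached to the amine nitrogen. In a functional assay on the whole organism for inhibition, with Rattus norvegicus as the target (a higher number here means that more compound is needed for the effect, a lower number that less compound is needed), compound 3 holds the second highest of the three numbers. Its nearest neighbour is compound 2, but the gap a 2.0-fold higher number from compound 2 to compound 3 (0.30 log units; within the scatter) lies within the scatter, so the two cannot be ranked against each other. Its furthest neighbour is compound 1, and the step of a 6.3-fold lower number from compound 1 to compound 3 (0.80 log units; beyond the scatter) is beyond the scatter, as is a 13-fold lower number from compound 1 to compound 2 (1.10 log units; beyond the scatter).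

Compound 4 `CC1CC/C(=N\Nc2ccc([N+](=O)[O-])cc2)c2ncc(C(=O)O)c(=O)n21` has not yet been tested in this assay. It differs from compound 3 by nitro in place of bromo on an aromatic carbon. Going by the values given here, no measured pair involves a nitro group, so no step bears directly on this change. Among the compounds with values here, the only step on the same ring position, 4-bromophenyl in place of 3-bromophenyl, gave a change within the scatter. With nothing pointing either way, compound 4 is expected to move by a 1.3-fold higher number from compound 3 to compound 4 (0.10 log units; within the scatter), that is, not beyond the scatter. Compound 4 is therefore estimated at 1 umol/kg, within a range from 0.4 umol/kg to 2.5 umol/kg.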

Compound 4, dose for 50% inhibition: 0.8 umol/kg
The estimate for compound 4 lay 1.3-fold (0.10 log units) above the measured number; the measured number falls inside the stated range.
By their numbers in this assay, from the lowest: compounds 2, 3 and 4 (each within the scatter of the next); then compound 1.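

On an aromatic carbon para to a large group, nitro in place of bromo gives no change at the digits printed from compound 3 to compound 4 (within the scatter) in this assay, so compound 3 and compound 4 cannot be told apart in this measurement. Going by these compounds alone, this is the first comparison of two different kinds of group at this position, and the change is not a small one on paper: bromo is a single heavy atom with no hydrogen-bond acceptors, while nitro brings three heavy atoms and two hydrogen-bond acceptors, yet the measured numbers stay level. Nothing available explains why such different groups give matching numbers in the whole animal, and the match does not show that the two groups act alike in any other respect.

As far as these compounds go, whether this holds for other groups remains open: an amine, a carboxylic acid or a longer chain such as butyl on the same aromatic carbon could give a number that stands clear of the scatter or one that does not. It is also open whether nitro would match bromo on a different carbon of the ring, as the compounds shown carry nitro in only one place.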